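Carrying a Small Methyl Step Across Two Cores

The compounds below may be only part of what the source reports. "The series", "measured", "known", "first", "only" and "open" are said of these compounds alone.

Measured compounds:
Compound 1, `COc1cc2c(Oc3ccc(NC(=O)c4nn(-c5ccccc5OC(F)(F)F)c(=O)cc4C)cc3F)ccnc2cc1OCCCN1CCCCC1`: 120 nM
Compound 2, `COc1cc2c(Oc3ccc(NC(=O)c4nn(-c5ccccc5OC(F)(F)F)c(=O)cc4C)cc3F)ccnc2cc1OCCCN1CCC(C)CC1`: 90 nM
Compound 3, `COc1cc2c(Oc3ccc(NC(=O)c4nn(-c5ccc(Cl)cc5)c(=O)cc4C)cc3F)ccnc2cc1OCCCN1CCCCC1`: 320 nM

All three compounds were tested in a functional assay on A549 cells (Homo sapiens) for inhibition, read by MTT assay, with a stated time of 72 h; on this read-out lower numbers stand for stronger inhibition and higher numbers for weaker inhibition. Compound 1 and compound 2 share one core and differ only in the change (methyl in place of hydrogen on a saturated ring carbon), which gave a 1.3-fold lower number from compound 1 to compound 2 (0.12 log units; within the scatter), so these two values do not separate from each other. Compound 3 carries a different core: the difference between the cores is 4-chlorophenyl in place of 2-(trifluoromethoxy)phenyl on an aromatic nitrogen, and with it came a 2.7-fold higher number from compound 1 to compound 3 (0.43 log units; beyond the scatter), leaving compound 3 with the highest number among the three measured compounds.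

Compound 4, `COc1cc2c(Oc3ccc(NC(=O)c4nn(-c5ccc(Cl)cc5)c(=O)cc4C)cc3F)ccnc2cc1OCCCN1CCC(C)CC1`, has not yet been measured in this assay. It differs from compound 3 by methyl in place of hydrogen on a saturated ring carbon, and the place of this change reads the same, word for word, as the place of the change from compound 1 to compound 2, so it is the same change applied to the other core. Because that earlier change produced a 1.3-fold lower number from compound 1 to compound 2 (0.12 log units; within the scatter), the step from compound 3 to compound 4 is expected to be of similar small size, a 1.3-fold lower number from compound 3 to compound 4 (0.11 log units; within the scatter), resting on that single precedent alone. Compound 4 is therefore estimated to give 250 nM in this assay, with a likely range from 120 nM to 520 nM, an expectation that the measurement will test.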

Compound 4, half-maximal inhibitory concentration: 210 nM
Compound 4: the middle estimate sits 1.2-fold (0.08 log units) above what was measured; the measured number falls inside the stated range.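

On the core of compound 3, the change from piperidin-1-yl to 4-methylpiperidin-1-yl came with a 1.5-fold lower number from compound 3 to compound 4 (0.18 log units; within the scatter) in this assay, and this step agrees with its counterpart on the other core: the same change on two cores in this assay, a 1.3-fold lower number (0.12 log units; within the scatter) from compound 1 to compound 2 and a 1.5-fold lower number (0.18 log units; within the scatter) from compound 3 to compound 4, 1.1-fold (0.06 log units) apart, within the scatter of two such steps Read the other way, with 4-methylpiperidin-1-yl held in place, 4-chlorophenyl in place of 2-(trifluoromethoxy)phenyl came with a 2.3-fold higher number from compound 2 to compound 4 (0.37 log units; beyond the scatter), and this step also agrees with its earlier counterpart: the same change on two cores in this assay, a 2.7-fold higher number (0.43 log units; beyond the scatter) from compound 1 to compound 3 and a 2.3-fold higher number (0.37 log units; beyond the scatter) from compound 2 to compound 4, 1.1-fold (0.06 log units) apart, within the scatter of two such steps Among these compounds, then, each change kept its size from one core to the other, but the evidence is only a single square of compounds in one cell assay, and since both methyl steps lie within the scatter, it shows neither that the methyl group itself alters the read-out nor that the agreement would extend to further cores.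

The compounds shown leave open whether a larger group such as an ethyl or a polar one such as a hydroxyl, placed on the same saturated ring carbon, would also carry from one core to the other. They also leave open whether a morpholine in place of the piperidine, or a pyridyl group on the aromatic nitrogen, would keep the steps this consistent.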